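Trimming the ether chain of compound 1 to a hydroxyl

The source may report more compounds than this note shows. Statements on the series, on what has been measured and on what is new or still open speak of the compounds shown alone.

Measured compounds:
- compound 1, `NCCOc1cc(-c2cccnc2)ccc1C(N)=O`: 820 nM
- compound 2, `Cc1n[nH]c(C)c1-c1cncc(-c2ccc(C(N)=O)c(OC(C)C)c2)c1`: 33 nM

Of the compounds shown here, two have been measured in an assay on cells for inhibition of MAP kinase-interacting serine/threonine-protein kinase 1 (Homo sapiens), read by mobility shift assay, with stated times of 10 min and 60 min, in the presence of a further agent that is not named here; a lower number here means a stronger inhibitor, a higher number a weaker inhibitor. Compound 1 carries the 2-aminoethoxy group on its core and gives 820 nM in this assay. Compound 2 differs from compound 1 in more than one place, and in this assay compound 2 gives 33 nM. Of the two numbers, compound 1 stands highest, so it is the weaker inhibitor; the gap to compound 2 is beyond the scatter. Among the compounds with values here, no pair that differs in only one place has been measured, so no single step has a known size here.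

Compound 3, `NC(=O)c1ccc(-c2cccnc2)cc1O`, is not yet measured. Its change from compound 1 is hydrogen in place of 2-aminoethyl on an oxygen on an aromatic ring. Because compound 1 gives 820 nM, the starting point is already modest, and removing the 2-aminoethyl chain takes away one hydrogen-bond donor and one acceptor. The expected step from compound 1 to compound 3 is a 3.0-fold higher number from compound 1 to compound 3 (0.48 log units; beyond the scatter), a loss somewhat beyond the scatter, with a weaker number for compound 3. Compound 3 is therefore estimated to give 2500 nM in this assay, within a range of 600 nM to 10000 nM.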

Compound 3, half-maximal inhibitory concentration: 4300 nM
For compound 3 the middle estimate is 1.7-fold (0.24 log units) below the measured one; the range from low to high includes it.
By their numbers in this assay, from the lowest: compound 2; then compound 1; then compound 3.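

Within the data shown here, removing the chain gives the first single change of known size in this assay, with a 5.2-fold higher number from compound 1 to compound 3 (0.72 log units; beyond the scatter) as hydrogen replaces 2-aminoethyl on the oxygen on the aromatic ring. Compound 1 and compound 2 differ in more than one place, so their gap could not be tied to any one group, whereas this pair shows that what sits on this oxygen changes the number by itself, and that the bare hydroxy compound is the weaker of the two. No supporting measurement here accounts for the size of this step.

The pair cannot separate the part played by the terminal amine from that of the two-carbon chain that carries it, since both leave together; a methoxy group or a 2-hydroxyethyl group on the same oxygen would divide those two parts. A longer chain ending in an amine, or a carboxylic acid at the end of the chain, would show whether the trend extends beyond the 2-aminoethoxy group, and the shared core may also alter the size of this step in other compounds.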